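The source may report more compounds than this note shows. Statements on the series, on what has been measured and on what is new or still open speak of the compounds shown alone.

Compound 3, with the structure `Cc1cccc(Cn2cc(CCCCC[C@@H]3SC[C@@H]4NC(=O)N[C@@H]43)nn2)c1`, stands in an assay on isolated protein for inhibition of biotin--protein ligase (Homo sapiens), read by scintillation counting, with a stated time of 10 min (a lower number here means a stronger inhibitor, a higher number a weaker inhibitor), only at a limit, giving > 16000 nM. Compound 1, `COc1cccc(Cn2cc(CCCCC[C@@H]3SC[C@@H]4NC(=O)N[C@@H]43)nn2)c1`, likewise gives a limit in this assay, > 16000 nM. Compound 2, `Nc1cccc(Cn2cc(CCCCC[C@@H]3SC[C@@H]4NC(=O)N[C@@H]43)nn2)c1`, also gives a limit there, > 16000 nM. Thus none of the measured steps can be read: a step that the two limits leave unreadable from compound 1 to compound 2, a step that the two limits leave unreadable from compound 1 to compound 3 and a step that the two limits leave unreadable from compound 2 to compound 3 are all hidden by the limits, because of the limit of > 16000 nM in this assay, at which 3 of the 3 values shown sit. Compound 4, `O=C1N[C@H]2[C@H](CS[C@H]2CCCCCc2cn(Cc3ccc(C(F)(F)F)cc3)nn2)N1`, differs from compound 3 by 4-(trifluoromethyl)phenyl in place of 3-methylphenyl on a saturated chain carbon bound to an aromatic nitrogen. No measured step bears on this change in a readable way, so nothing in the shown values points toward a gain. Compound 4 is therefore expected to remain at the limit as well, and the estimate is 16000 nM, lying between 5000 nM and 50000 nM, with the expected step of a number no higher from compound 3 to compound 4 (the limit leaves the size open).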

Compound 4, inhibition constant: > 16000 nM
Compound 4: no number, only a limit; the forecaster's own chance of this, stated with the estimate: 75%; the middle value sits exactly at the limit.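

In this assay compound 4 gives only a limit, > 16000 nM. Its steps from compound 1, compound 2 and compound 3 therefore cannot be read: the limit of > 16000 nM in this assay, at which 4 of the 4 values shown sit.

The compounds shown leave open how any of these aromatic groups affects inhibition.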